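A Nitro Group Enters Where a Hydrogen Stood

A few compounds are considered here, and "the series" means these few. Any claim that something is new, unique, unknown or untested is made for them only; others in the source may bear on it.

Measured so far:
Compound 1, `O=c1ccc2cc(OCc3cc(-c4ccccc4)no3)ccc2o1`: in a functional assay on COLO 205 cells (Homo sapiens) for cytotoxicity, read by MTT assay, with a stated time of 48 h (a lower number here means a stronger inhibitor, a higher number a weaker inhibitor), compound 1 gives "not determined" (no result reported).
Compound 2, `O=c1ccc2cc(OCc3cc(-c4cccc5ccccc45)no3)ccc2o1`: 47200 nM.
Compound 3, `O=c1ccc2cc(OCc3cc(-c4ccccc4[N+](=O)[O-])no3)ccc2o1`: compound 3 gives "not determined" (no result reported).

Compound 1 stands without a number in this assay, and compound 3 shares that gap; only compound 2 carries a result, and its value in this assay, 47200 nM, is a weak one. Compound 4, `O=c1ccc2cc(OCc3cc(-c4ccc([N+](=O)[O-])cc4)no3)ccc2o1`, differs from compound 1 by one change: nitro in place of hydrogen on an aromatic carbon. Among the measured compounds shown here, no measured pair shows the size of this step, so no direction beyond the usual scatter can be claimed for it. The expectation for compound 4 rests on the weak value of compound 2, 47200 nM, the lone anchor in this series. Compound 4 is therefore expected to come out weak as well, estimated at 40000 nM, between 10000 nM and 150000 nM.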

Compound 4, half-maximal inhibitory concentration: 47800 nM
Compound 4: middle estimate off by 1.2-fold (0.08 log units), on the low side; measured number inside the range.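

Compound 1 has no number here, so the step from compound 1 to compound 4 cannot be read. Going by these compounds, whether nitro in place of hydrogen strengthens or weakens compound 1 stays open, and nothing available bears on the result of compound 4.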